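Microsomal stability notes: compound 3 to compound 4

The source may hold more compounds than are shown below. What is called first, only, known or untested is meant among the compounds shown, and "the series" means these compounds.

Measured compounds:
compound 1 `Cc1nc(N)nc(N[C@@H](C)c2cc3ccc(F)cn3c(=O)c2-c2ccccc2)c1C#N`: 8%
compound 2 `C[C@H](Nc1ncnc(N)c1C#N)c1cc(=O)n2cc(F)ccc2c1-c1cc(F)cc(F)c1`: 57%
compound 3 `Cc1c([C@H](C)Nc2nc(N)nc(N)c2C#N)c(-c2ccccc2)c(=O)n2cc(F)ccc12`: 85%

In an ADME assay on microsomes from liver (Mus musculus), read by LC-MS, using NADPH, with a stated time of 30 min, tested at 1 uM (a higher number here means that more of the compound is left, a lower number that less of the compound is left), compound 3 gives 85%, the highest of the three numbers; compound 2 sits below it by a gap beyond the scatter, and compound 1 further below still. Compounds 1 and 2 differ from compound 3 in more than one place, so their values show only where they stand, not what any single change does.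

Compound 4 `C[C@H](Nc1nc(N)nc(N)c1C#N)c1c(-c2ccccc2)c(=O)n2cc(F)ccc2c1-c1ccc(C(N)=O)cc1` is not yet measured. It differs from compound 3 by 4-carbamoylphenyl in place of methyl on an aromatic carbon. For the measured compounds named here, no measured pair in this set isolates such a change, so the expected size of the step rests on nothing more than the general spread of the three values. A moderate fall from the top of the series is expected rather than none; an unchanged or higher figure cannot be excluded.

The estimated step from compound 3 to compound 4 in this assay is a number 25 percentage points lower from compound 3 to compound 4 (beyond the scatter). Compound 4 is expected to give 60%, within 25% to 90%.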

Compound 4, percent of the compound remaining: 97%
The estimate for compound 4 lay 37 percentage points below the measured number; the measured number lies above the stated range.
By their numbers in this assay, from the lowest: compound 1; then compound 2; then compound 3; then compound 4.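

In this assay, the series now has its first step that changes one place only: a number 12 percentage points higher from compound 3 to compound 4 (beyond the scatter), with 4-carbamoylphenyl in place of methyl on the aromatic carbon ortho to a fused ring. This position therefore takes a much larger group, bringing an added aromatic ring and a hydrogen-bond donor, with no loss in the percentage of compound remaining. Methyl at this carbon is thus not needed for the high number seen with compound 3, a point that compounds 1 and 2 could not settle.

Still open, from the compounds shown here alone, is whether the step follows the carboxamide or the phenyl ring alone, which a plain phenyl, a 4-carboxyphenyl or a 4-(aminomethyl)phenyl group at this carbon would help to separate. No measurement at hand gives a cause for the step.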